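A Chain Methyl on a Compound at the Assay Limit

This account rests on a few compounds, and the source may have more. Where it says the series, first, only, none or still open, it means among the compounds named here.

Compound 1 `CC(=O)N(C)CC#CCN1CCCC1`: > 10 mg/kg
Compound 2 `COC(=O)N(C)C(C)C#CCN1CCCC1`: > 100 mg/kg
Compound 3 `CCOC(=O)N(C)CC#CCN1CCCC1`: > 100 mg/kg

All three results come from a functional assay on the whole organism for antagonist activity, with Mus musculus as the target (a higher number here means that more compound is needed for the effect, a lower number that less compound is needed), and each one is a limit rather than a number. Compound 3 stands at the limit of > 100 mg/kg. This is the limit of > 100 mg/kg in this assay, at which 2 of the 3 values shown sit.

Compound 4 `CCOC(=O)N(C)C(C)C#CCN1CCCC1` differs from compound 3 in one place: methyl in place of hydrogen on a saturated chain carbon bound to an amide-type nitrogen and a triple-bonded carbon. In words, this is methyl in place of hydrogen on a saturated chain carbon bound to an amide-type nitrogen and a triple-bonded carbon.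

Among the compounds with values here, the only measured step is a step that the two limits leave unreadable from compound 1 to compound 3. It is a different change, so it gives no size for this one. Compound 2 already carries a methyl on such a chain carbon, and its result is also a limit, > 100 mg/kg. That limit is the closest guide, so no step beyond the usual scatter is expected in this assay.

The expected step is a step that the limit leaves unreadable from compound 3 to compound 4. Compound 4 is estimated at 150 mg/kg, with an expected range of 60 mg/kg to 400 mg/kg, and this assay may well report only a limit again.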

Compound 4, dose for half-maximal effect: 97 mg/kg
Compound 4: the middle estimate sits 1.5-fold (0.19 log units) above what was measured; the measured number falls inside the stated range.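

In this assay, within the data shown here, compound 4 gives 97 mg/kg, the first measured number in this small set rather than a limit. Methyl in place of hydrogen on a saturated chain carbon bound to an amide-type nitrogen and a triple-bonded carbon gives an at least 1.0-fold lower number from compound 3 to compound 4 (0.01 log units; that floor lies within the scatter), and methyl in place of hydrogen on a saturated chain carbon bound to an oxygen next to a carbonyl group gives an at least 1.0-fold lower number from compound 2 to compound 4 (0.01 log units; that floor lies within the scatter). From the compounds shown here alone, each step is known only as a floor, so the data show that a compound carrying both methyl groups can be given a number in this assay, while the true size of either step stays unknown.

The compounds shown leave open whether an ethyl or hydroxymethyl group on the same chain carbon would give a different number. They also leave open what the same methyl would do on the core of compound 1.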